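A third methoxy group on compound 2: expected edema inhibition

The source may hold more compounds than are shown below. What is called first, only, known or untested is meant among the compounds shown, and "the series" means these compounds.

Compound 1 `COc1cc(-c2nnc(SCC(=O)Nc3ccc(/C(C)=N/O)cc3)n2-c2ccccc2)cc(OC)c1OC` and compound 2 `CCn1c(SCC(=O)Nc2ccc(/C(C)=N/O)cc2)nnc1-c1ccc(OC)c(OC)c1` were both tested in a functional assay on the whole organism (strain albino) for inhibition, with Rattus norvegicus as the target, read by paw edema, with stated times of 30 min and 3 h, at a dose of 0.28 mmol/kg by the oral route; on this read-out higher numbers stand for more inhibition at the one dose given (going by the name of the read-out) and lower numbers for less inhibition. Compound 1 gives 66%, and compound 2 gives 66%, so compound 2 stands level with compound 1 at the digits reported, its nearest neighbour, with no difference beyond the usual scatter. The two compounds differ in more than one place, so their matching read-outs say only that both inhibit paw edema alike at this dose. Compound 3 `CCn1c(SCC(=O)Nc2ccc(/C(C)=N/O)cc2)nnc1-c1cc(OC)c(OC)c(OC)c1` has not yet been measured. It is reached from compound 2 by methoxy in place of hydrogen on an aromatic carbon, a methoxy in place of hydrogen on an aromatic carbon. Since compound 1, which also carries three methoxy groups, gives 66% while compound 2 gives 66%, the expected step of no change at the digits printed from compound 2 to compound 3 (within the scatter) is none beyond the scatter. Compound 3 is therefore estimated at 66%, within a range from 55% to 76%.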

Compound 3, a percentage reported as inhibition, in the whole organism at one dose (the size of the read-out at that dose, not a potency): 70%
For compound 3 the middle estimate is 4 percentage points below the measured one, within the range that was stated.
By their numbers in this assay, from the lowest: compounds 1, 2 and 3 (each within the scatter of the next).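

In this assay methoxy in place of hydrogen on an aromatic carbon, ortho to a methoxy group, gives a number 4 percentage points higher from compound 2 to compound 3 (within the scatter) and thus shows that this position accepts the added group with no shift beyond the scatter. Compound 3 also links the two earlier series through a single change: ethyl in place of phenyl on an aromatic nitrogen gives a number 4 percentage points higher from compound 1 to compound 3 (within the scatter) and likewise leaves the read-out within the scatter at this dose. Nothing in the data given accounts for either result.

Going by these compounds, whether a hydroxyl, an amine or a longer alkoxy chain at this position would hold the read-out remains open. So does the effect of a benzyl group or a longer alkyl chain on the aromatic nitrogen, and these single-dose values give no potency for any compound.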